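Amino in Place of Chloro: Compound 4 Expected

The source may hold more compounds than are shown below. What is called first, only, known or untested is meant among the compounds shown, and "the series" means these compounds.

Three compounds have been measured in a functional assay on DU-145 cells (Homo sapiens) for inhibition, read by trypan blue exclusion, with a stated time of 96 h; on this read-out lower numbers stand for stronger inhibition of growth and higher numbers for weaker inhibition of growth:
- compound 1 `O=C(O)c1ccc(C(=O)/C(=C\c2ccc(F)c([N+](=O)[O-])c2)SCc2ccc(F)cc2)cc1`: 1000 nM
- compound 2 `COc1ccc(/C=C(/SCc2ccc(F)cc2)C(=O)c2ccc(C(=O)O)cc2)cc1O`: 10000 nM
- compound 3 `O=C(O)c1ccc(C(=O)/C(=C\c2ccc(Cl)c([N+](=O)[O-])c2)SCc2ccc(F)cc2)cc1`: 1000 nM

Compound 3 stands level with compound 1, and together they give the lowest numbers of the three; compound 2 is the furthest from it, with a 10-fold lower number from compound 2 to compound 3 (1.00 log units; beyond the scatter) describing the gap in the other direction. Compound 1 and compound 3 differ only by a halogen on the ring, and no change at the digits printed from compound 1 to compound 3 (within the scatter) shows that this exchange left the read-out unchanged. The larger step, a 10-fold higher number from compound 1 to compound 2 (1.00 log units; beyond the scatter), comes from swapping the whole 4-fluoro-3-nitrophenyl group for 3-hydroxy-4-methoxyphenyl and does not touch the same place as the next change.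

Compound 4 `Nc1ccc(/C=C(/SCc2ccc(F)cc2)C(=O)c2ccc(C(=O)O)cc2)cc1[N+](=O)[O-]` differs from compound 3 by amino in place of chloro on an aromatic carbon. Among the measured compounds shown here, no measured step shows an amino group at this place; the only step on this carbon, no change at the digits printed from compound 1 to compound 3 (within the scatter), exchanged one halogen for another. With the nitro group kept, the author expects a small shift, a 1.5-fold higher number from compound 3 to compound 4 (0.18 log units; within the scatter), most likely within the scatter or a little toward weaker inhibition. Compound 4 is therefore estimated at 1500 nM, with a range from 500 nM to 5000 nM.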

Compound 4, concentration for 50% growth inhibition: 10000 nM
Estimate against measurement, compound 4: 6.7-fold (0.82 log units) below, and the stated range ends below it.
By their numbers in this assay, from the lowest: compounds 1 and 3 (each within the scatter of the next); then compounds 2 and 4 (each within the scatter of the next).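

In this assay, among the compounds shown here, this ring carbon, ortho to a nitro group and para to a large group, had so far held only halogens, and the exchange between them gave no step beyond the scatter; the amino group shows that the position is not indifferent to what it carries, with a 10-fold higher number from compound 3 to compound 4 (1.00 log units; beyond the scatter) and, against the fluoro compound, a 10-fold higher number from compound 1 to compound 4 (1.00 log units; beyond the scatter). The nitro group alone therefore does not keep the number low, as compound 4 carries it and yet shows no change at the digits printed from compound 2 to compound 4 (within the scatter), so the 4-amino-3-nitrophenyl and 3-hydroxy-4-methoxyphenyl groups read alike here, and the earlier link between a nitro-bearing ring and the lower number does not hold for compound 4. Nothing available gives an independent measurement that would explain this step.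

The compounds shown leave open whether a methyl, hydroxyl or dimethylamino group at this carbon would read like the halogens or like the amino group. They also leave open whether the amino step would be the same size with a nitrile in place of the nitro group.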